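A Fluorine Swap Repeated on a Second Core

A few compounds are considered here, and "the series" means these few. Any claim that something is new, unique, unknown or untested is made for them only; others in the source may bear on it.

Compound 1 `C=C1C(=O)[C@]23C[C@@]1(O)CC[C@H]2c1ccc(O)c(C)c1[C@@H]3Cn1cc(-c2ccccc2)nn1` and compound 2 `C=C1C(=O)[C@]23C[C@@]1(O)CC[C@H]2c1ccc(O)c(C)c1[C@@H]3Cn1cc(-c2ccc(F)cc2)nn1` are built on one core, while compound 3 `C=C1C[C@]23C[C@@]1(O)CC[C@@H]2c1cccc(C)c1[C@@H]3Cn1cc(-c2ccccc2)nn1` and the not yet measured compound 4 `C=C1C[C@]23C[C@@]1(O)CC[C@@H]2c1cccc(C)c1[C@@H]3Cn1cc(-c2ccc(F)cc2)nn1` are built on another; the difference between the two cores is not broken down here. In a functional assay on HL-60 cells (Homo sapiens) for cytotoxicity, read by MTT assay, with a stated time of 4 days (a higher number here means a weaker inhibitor, a lower number a stronger inhibitor), compound 1 gives 750 nM. In this assay compound 2 gives 660 nM. The change from compound 1 to compound 2 is fluoro in place of hydrogen on an aromatic carbon and it gave a 1.1-fold lower number from compound 1 to compound 2 (0.06 log units; within the scatter), so the two compounds cannot be told apart by this reading.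

For compound 3, this assay reports only a limit, > 20000 nM, and no number. That value sits at the limit of > 20000 nM in this assay, at which 1 of the 3 values shown sits.

Going by the values given here, compound 4 differs from compound 3 by fluoro in place of hydrogen on an aromatic carbon, the same change as the one made from compound 1 to compound 2, at the same kind of place on the same kind of ring. Since the earlier step was only a 1.1-fold lower number from compound 1 to compound 2 (0.06 log units; within the scatter), compound 4 is expected to land where compound 3 lands, at or beyond the limit of this assay. Compound 4 is accordingly estimated at about 25000 nM, within a range of 10000 nM to 60000 nM, and most likely the measurement again returns a limit rather than a number. In step terms this expectation amounts to an estimated step that the limit leaves unreadable from compound 3 to compound 4.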

Compound 4, half-maximal inhibitory concentration: > 20000 nM
Compound 4 gave a limit, no number; the forecaster's own chance of this, stated with the estimate: 75%; the middle value lies beyond the limit too.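

In this assay compound 4 gives a limit (> 20000 nM) and no number. Compound 3 also stands at a limit in this assay, so no new step can be read from compound 3 to compound 4: the limit of > 20000 nM in this assay, at which 2 of the 4 values shown sit.

The compounds shown leave open whether fluoro in place of hydrogen on an aromatic carbon changes the reading at all on the core of compound 3.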